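Chloro Added to the Pyridine Ring of Compound 1

A few compounds are considered here, and "the series" means these few. Any claim that something is new, unique, unknown or untested is made for them only; others in the source may bear on it.

Measured compounds:
- compound 1 `CN1CCC[C@H]1COc1cccnc1`: 0.15 nM
- compound 2 `CN1CCC[C@H]1COc1cccnc1I`: 606 nM
- compound 3 `CN1CCC[C@H]1COc1cnccc1Br`: 28 nM

In an assay on membranes from brain for displacement of a labelled ligand from Neuronal acetylcholine receptor; alpha4/beta2 (Rattus norvegicus) (on this read-out lower numbers stand for stronger inhibition and higher numbers for weaker inhibition), compound 1 gives 0.15 nM, the lowest of the three numbers; compound 3 comes nearest and compound 2 lies furthest away. Compound 4 `CN1CCC[C@H]1COc1cncc(Cl)c1` has not yet been measured. It differs from compound 1 by chloro in place of hydrogen on an aromatic carbon.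

Among the compounds with values here, two measured steps bear on this change, both adding a halogen to the same aromatic ring of the shared core: a 4000-fold higher number from compound 1 to compound 2 (3.61 log units; beyond the scatter) and a 190-fold higher number from compound 1 to compound 3 (2.27 log units; beyond the scatter). Both are large losses. Neither places the halogen at the position taken by chloro in compound 4, and neither is a chloro, so they fix the direction more firmly than the size. Compound 4 is therefore expected to give a higher number than compound 1, the step of a 13-fold higher number from compound 1 to compound 4 (1.12 log units; beyond the scatter) being estimated as smaller than either measured halogen step. The estimate for compound 4 in this assay is 2 nM, with a range from 0.2 nM to 20 nM.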

Compound 4, inhibition constant: 0.6 nM
Compound 4: the middle estimate sits 3.3-fold (0.52 log units) above what was measured; low and high end bracket the measured number.
By their numbers in this assay, from the lowest: compound 1; then compound 4; then compound 3; then compound 2.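

At this position, on an aromatic carbon two atoms from the ring nitrogen, chloro costs something real but modest in this assay: the change brings a 4.0-fold higher number from compound 1 to compound 4 (0.60 log units; beyond the scatter), a step beyond the scatter. A halogen on the pyridine ring of compound 1 therefore need not bring a loss on the scale of a 190-fold higher number from compound 1 to compound 3 (2.27 log units; beyond the scatter) or a 4000-fold higher number from compound 1 to compound 2 (3.61 log units; beyond the scatter). Nothing given here explains the smaller step.

Compound 4 differs from compound 2 and compound 3 in both the halogen and its place, so the compounds shown leave open whether the smaller step belongs to chloro, to this position, or to both. They also leave open how bromo, iodo, an amine or a carboxylic acid would fare at this same position.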